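Swapping thiophen-2-yl for propylamino on compound 3

The source may hold more compounds than are shown below. What is called first, only, known or untested is meant among the compounds shown, and "the series" means these compounds.

Values measured in a physicochemical assay for solubility, at pH 7 (a higher number here means a more soluble compound, a lower number a less soluble compound), are
- Compound 1 `CC(C)(C)C(=O)N1Cc2c(NC(=O)C3CCNCC3)n[nH]c2C1(C)C` gives > 225000 nM as a limit of the assay
- Compound 2 `CC(=O)N1CCC(C(=O)N2Cc3c(NC(=O)c4ccc(F)cc4)n[nH]c3C2(C)C)CC1` gives 204000 nM
- Compound 3 `CN1CCC(C(=O)N2Cc3c(NC(=O)c4cccs4)n[nH]c3C2(C)C)CC1` gives 155000 nM

Compound 3 stands within the scatter of compound 2 (204000 nM), so these two numbers cannot be told apart. Compound 1 has only a limit and no number.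

Compound 4 `CCCNC(=O)Nc1n[nH]c2c1CN(C(=O)C1CCN(C)CC1)C2(C)C` carries propylamino in place of thiophen-2-yl on a carbonyl carbon and has not yet been measured. For the measured compounds named here, no measured pair shows this change alone. Starting from compound 3 (155000 nM), no step beyond the scatter is expected in this assay for this change. The expected change is small (a 1.2-fold higher number from compound 3 to compound 4 (0.09 log units; within the scatter)). Compound 4 is estimated at 190000 nM (range 110000 nM to 240000 nM).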

Compound 4, solubility: > 225000 nM
Compound 4 was reported as a limit; the forecaster's own chance of this, stated with the estimate: 30%; middle value at least 1.1-fold (0.07 log units) from the limit.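

In this assay, the swap on this carbonyl carbon reads as an at least 1.4-fold higher number from compound 3 to compound 4 (0.16 log units; that floor lies within the scatter), so the number does not fall when the aromatic thiophen-2-yl ring gives way to the open propylamino chain. Compound 4 gives > 225000 nM, which is a limit of the assay and not a number. The full size of the step cannot be read, because the read-out stops at a ceiling: the limit of > 225000 nM in this assay, at which 2 of the 4 values shown sit.

As far as these compounds go, whether a longer chain or a carboxylic acid on this carbonyl carbon would also reach that limit remains open.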